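Chloro on the anilide ring, in thiol and thioester series

The source may report more compounds than this note shows. Statements on the series, on what has been measured and on what is new or still open speak of the compounds shown alone.

Compound 1 `O=C(CCCCC(S)CCS)Nc1ccccc1` and compound 2 `O=C(CCCCC(S)CCS)Nc1ccc(Cl)cc1` share one core; in a functional assay on KB cells (Homo sapiens) for inhibition, read by MTT assay, with a stated time of 24 h, tested at 0.1 ug/mL (a lower number here means less inhibition of growth, a higher number more inhibition of growth at the concentration tested), compound 1 gives 9.49% and compound 2 gives 9.11%. The two differ in a single place, (chloro in place of hydrogen on an aromatic carbon), and this change produced a step of a number 0.4 percentage points lower from compound 1 to compound 2 (within the scatter). Compound 3 `CC(=O)SCCC(CCCCC(=O)Nc1ccccc1)SC(C)=O` has the same anilino part, but how its core differs from that of compound 1 is not broken down here; in this assay compound 3 gives 7.24%, a number that lies within the usual scatter of both compound 1 and compound 2. Compound 4 `CC(=O)SCCC(CCCCC(=O)Nc1ccccc1Cl)SC(C)=O` has not yet been measured. It differs from compound 3 by chloro in place of hydrogen on an aromatic carbon; this is the same kind of change as that from compound 1 to compound 2, though here the chloro is ortho to a large group, whereas in compound 2 it is para to a large group. Since the earlier step of a number 0.4 percentage points lower from compound 1 to compound 2 (within the scatter) hardly moved the number, compound 4 is expected to give 7.5% in this assay, with a likely range from 2% to 16%. The step of a number 0.3 percentage points higher from compound 3 to compound 4 (within the scatter) implied by this estimate is expected to stay small.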

Compound 4, percent growth inhibition at one concentration: 7.05%
The estimate for compound 4 lay 0.5 percentage points above the measured number, and the stated range covers the measured number.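

In this assay, chloro in place of hydrogen on an aromatic carbon gave a number 0.2 percentage points lower from compound 3 to compound 4 (within the scatter), and this step does not differ from the one seen on the core of compound 1: the same change on two cores in this assay, a number 0.4 percentage points lower (within the scatter) from compound 1 to compound 2 and a number 0.2 percentage points lower (within the scatter) from compound 3 to compound 4, 0.2 percentage points apart, within the scatter of two such steps Within these two pairs, the change therefore carried from one core to the other without a visible difference, and on neither core did it move the number beyond the scatter. This does not show that chloro leaves growth inhibition unchanged on other cores or at other concentrations, nor does it separate core from position, since the chloro of compound 4 stands ortho to a large group while that of compound 2 stands elsewhere on the ring.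

On these data alone, whether a methoxy, an amine or a carboxylic acid on the ring, or a longer chain in place of the present one, would move the number beyond the scatter remains open. Also open, as far as these compounds go, is how the two cores would compare with chloro at the same place on the ring.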